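Hydroxyphenyl position change carried to a second core

This account rests on a few compounds, and the source may have more. Where it says the series, first, only, none or still open, it means among the compounds named here.

Compound 1 `Oc1cccc(-c2cc(-c3ccsc3)cc(-c3cccc(O)c3)n2)c1` gives 1310 nM in a functional assay on DU-145 cells (Homo sapiens) for cytotoxicity, read by CCK-8 assay; on this read-out higher numbers stand for weaker inhibition and lower numbers for stronger inhibition. Compound 2 `Oc1ccc(-c2cc(-c3ccsc3)cc(-c3cccc(O)c3)n2)cc1` gives 2230 nM in this assay, and the step of a 1.7-fold higher number from compound 1 to compound 2 (0.23 log units; within the scatter) belongs to the change (4-hydroxyphenyl in place of 3-hydroxyphenyl on an aromatic carbon). Compound 3 `Oc1cccc(-c2cc(-c3ccco3)cc(-c3ccccc3O)n2)c1` gives 1790 nM in this assay; the difference between the core of compound 3 and the core of compound 1 is not broken down here. Compound 4 `Oc1ccc(-c2cc(-c3ccco3)cc(-c3ccccc3O)n2)cc1` is not yet measured and differs from compound 3 by 4-hydroxyphenyl in place of 3-hydroxyphenyl on an aromatic carbon. This is the same kind of change as that from compound 1 to compound 2, but the surroundings differ: in compound 1 the place is meta to a 3-hydroxyphenyl group and meta to a thiophen-3-yl group, while in compound 3 it is meta to a 2-hydroxyphenyl group and meta to a furan-2-yl group. The expected step of a 1.6-fold higher number from compound 3 to compound 4 (0.21 log units; within the scatter) in this assay is set close to the earlier one, resting on the size of a 1.7-fold higher number from compound 1 to compound 2 (0.23 log units; within the scatter) from compound 1 to compound 2. On that basis compound 4 is estimated at 2900 nM in this assay, with a range from 1500 nM to 5600 nM.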

Compound 4, half-maximal inhibitory concentration: > 50000 nM
Compound 4 ended at the assay's limit (the forecaster's own chance of this, stated with the estimate: 5%); middle value at least 17-fold (1.23 log units) from the limit.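

In this assay compound 4 gives > 50000 nM, which is a limit of the assay and not a number. The step of an at least 27-fold higher number from compound 3 to compound 4 (1.44 log units; beyond the scatter) therefore fixes only a bound on its size, yet this is enough to show that the change from 3-hydroxyphenyl to 4-hydroxyphenyl does not carry over in size between these two cores: the same change on two cores in this assay, a 1.7-fold higher number (0.23 log units; within the scatter) from compound 1 to compound 2 and an at least 27-fold higher number (1.44 log units; beyond the scatter) from compound 3 to compound 4, at least 16-fold (1.21 log units) apart, beyond the scatter of two such steps It does not show which difference between the cores matters, since the core of compound 3 has furan-2-yl and 2-hydroxyphenyl groups where the core of compound 1 has thiophen-3-yl and 3-hydroxyphenyl groups, and it does not give the true size of the step.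

Open, going by these compounds, is whether exchanging furan-2-yl for thiophen-3-yl alone, or 2-hydroxyphenyl for 3-hydroxyphenyl alone, is enough to reproduce the large step. Also open, on these data alone, is whether a methoxy group or an amine in place of the hydroxyl of the 4-hydroxyphenyl group would give a similar read-out on either core.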